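Cyclopropane substituent change in a biphenyl amide series

A few compounds are considered here, and "the series" means these few. Any claim that something is new, unique, unknown or untested is made for them only; others in the source may bear on it.

Measured compounds:
compound 1, `CC(C)C[C@H](N)CN(C(=O)[C@@H]1C[C@H]1c1ccccc1)c1ccc(-c2ccccc2)cc1`, 880 nM
compound 2, `CCC(CC)C(N)CCN(C(=O)[C@@H]1C[C@H]1c1ccccc1)c1ccc(-c2ccccc2)cc1`, 2 nM
compound 3, `CC[C@H](C)[C@H](N)CN(C(=O)[C@@H]1C[C@H]1c1cccc(Cl)c1)c1ccc(-c2ccccc2)cc1`, 2200 nM

Readings come from a functional assay for agonist activity at G protein-coupled receptor 88 (Homo sapiens), read by HTRF and cAMP accumulation; on this read-out higher numbers stand for an effect only at larger amounts of compound and lower numbers for an effect already at smaller amounts. On these numbers compound 3 stands highest of the three: compound 1 sits below it, and compound 2 sits far below both, each gap beyond the scatter.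

For the measured compounds named here, the one step between measured compounds that differ in one place is a 440-fold lower number from compound 1 to compound 2 (2.64 log units; beyond the scatter). That change sits on the saturated chain carbon bound to the amide-type nitrogen and leaves the cyclopropane substituent untouched.

Compound 4, `CC[C@H](C)[C@H](N)CN(C(=O)[C@@H]1C[C@H]1C1CCCCC1)c1ccc(-c2ccccc2)cc1`, is not yet measured in this assay. It differs from compound 3 by cyclohexyl in place of 3-chlorophenyl on a saturated ring carbon, on a saturated ring carbon of a three-membered non-aromatic ring of carbon only. No measured pair varies that position: compounds 1, 2 and 3 all carry a phenyl or 3-chlorophenyl there, so the step from compound 1 to compound 2 does not bear on this change, and no direction beyond the scatter can be argued from the shown data. The working expectation is therefore a number close to that of compound 3, with wide uncertainty in both directions.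

For compound 4 the estimated value in this assay is 3000 nM, between 500 nM and 20000 nM, which corresponds to an expected step of a 1.4-fold higher number from compound 3 to compound 4 (0.13 log units; within the scatter).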

Compound 4, half-maximal effective concentration: > 25000 nM
Compound 4: a limit, no number; the forecaster's own chance of this, stated with the estimate: 15%; at least 8.3-fold (0.92 log units) between middle value and limit.
By their numbers in this assay, from the lowest: compound 2; then compound 1; then compound 3. At a limit, above all of these: compound 4.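

Cyclohexyl in place of 3-chlorophenyl on a saturated ring carbon of the three-membered ring gives an at least 11-fold higher number from compound 3 to compound 4 (1.05 log units; beyond the scatter) in this assay, the only step shown at this position. The result for compound 4 is a limit of the assay and not a number, so the step has a floor but no upper end: the limit of > 25000 nM in this assay, at which 1 of the 4 values shown sits. The earlier compounds shown here all carried an aromatic ring here and could not show whether this position matters, whereas this step shows that, with the rest of compound 3 unchanged, a six-membered non-aromatic ring of carbon only does not retain even the weak response of compound 3.

Since 3-chlorophenyl loses both its chlorine and its aromatic ring in this change, the two cannot be separated, as plain phenyl appears only with other amine chains, in compound 1 and compound 2. Also open, as far as these compounds go, are how a pyridine ring or a cyclopentyl group would read at this carbon, and whether cyclohexyl would cost as much on the chain of compound 2, which stands at 2 nM.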